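The source may report more compounds than this note shows. Statements on the series, on what has been measured and on what is new or still open speak of the compounds shown alone.

Compound 1, `COc1ccc(C2=C(c3ccc(SC)cc3)CC3CCCN3C2=O)cc1O`: > 100000 nM
Compound 2, `CSc1ccc(C2=C(c3ccc(C)c(C)c3)C(=O)N3CCCC3C2)cc1`: 300 nM
Compound 3, `CSc1ccc(C2=C(c3ccc(OCC4CO4)cc3)C(=O)N3CCCC3C2)cc1`: 10000 nM

The three measured compounds share one core and differ only in the aryl group on the double-bonded ring carbon. In a functional assay on SK-OV-3 cells (Homo sapiens) for cytotoxicity (on this read-out higher numbers stand for weaker inhibition of growth and lower numbers for stronger inhibition of growth), compound 1 gives > 100000 nM, which is a limit of the assay rather than a number. Going by the values given here, compound 1 thus sits at the limit of > 100000 nM in this assay, at which 1 of the 3 values shown sits, and is the only measured compound with no numerical value. Compound 2 gives 300 nM in this assay, and compound 3 gives 10000 nM.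

Compound 4, `CSc1ccc(C2=C(c3ccc(F)cc3)C(=O)N3CCCC3C2)cc1`, has not yet been measured in this assay. It departs from compound 1 in one place: 4-fluorophenyl in place of 3-hydroxy-4-methoxyphenyl on a double-bonded ring carbon.

Among the compounds with values here, the only measured step that bears on this change is an at least 330-fold lower number from compound 1 to compound 2 (2.52 log units; beyond the scatter), a large move in the same direction, away from the limit, when a hydroxy-methoxy-substituted phenyl is exchanged for a plainer aryl group. Compound 3 shows that not every such exchange reaches as far as compound 2. Compound 4 carries the small 4-fluorophenyl group, closer in kind to the 3,4-dimethylphenyl of compound 2 than to the epoxide-bearing group of compound 3, so a large step down from the limit is expected. The expected step is an at least 100-fold lower number from compound 1 to compound 4 (2.00 log units; beyond the scatter). Compound 4 is therefore estimated to give 1000 nM in this assay, with a range from 200 nM to 10000 nM.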

Compound 4, concentration for 50% growth inhibition: 30000 nM
Compound 4: middle estimate off by 30-fold (1.48 log units), on the low side, outside the stated range (above it).
By their numbers in this assay, from the lowest: compound 2; then compound 3; then compound 4. At a limit, above all of these: compound 1.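

In this assay, compound 1 stands at a limit and not at a number, so the exchange for 4-fluorophenyl can be read only as a bound, an at least 3.3-fold lower number from compound 1 to compound 4 (0.52 log units; beyond the scatter): the limit of > 100000 nM in this assay, at which 1 of the 4 values shown sits.

The two aryl groups without a hydroxy or methoxy group are far apart at this position, with a 100-fold higher number from compound 2 to compound 4 (2.00 log units; beyond the scatter), so the loss of the 3-hydroxy-4-methoxyphenyl does not by itself bring the low number of compound 2, and the 3,4-dimethylphenyl stands out among the aryl groups compared. Going by these compounds alone, on the same aryl ring, the exchange of (oxiran-2-yl)methoxy for fluoro gives a 3.0-fold higher number from compound 3 to compound 4 (0.48 log units; beyond the scatter), so compound 4 ranks behind compound 3 as well, and compound 2 remains the only compound here with a number this low.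

The compounds shown leave open whether a single methyl would be enough, as a 4-methylphenyl would tell, and how a 4-chlorophenyl would compare with the 4-fluorophenyl of compound 4. They also leave open what an amine or a carboxylic acid on this aryl ring would do to growth inhibition.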